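The source may hold more compounds than are shown below. What is called first, only, known or untested is meant among the compounds shown, and "the series" means these compounds.

In an ADME assay on HEp-2 cells (Homo sapiens) for cytotoxicity (on this read-out higher numbers stand for lower toxicity in this test and lower numbers for higher toxicity in this test), three compounds on a shared core have been measured. Compound 1 (`CC(C)CCn1c(Cn2c(=O)n(C(C)C)c3ccccc32)nc2cc(C(C)(C)N)ccc21`) gives 3270 nM, compound 2 (`CC(C)CCn1c(Cn2c(=O)n(CC(=O)O)c3ccccc32)nc2cc(C(=N)N)ccc21`) gives 173000 nM, and compound 3 (`CC(C)CCn1c(Cn2c(=O)n(C(C)C)c3ccccc32)nc2ccc(C#N)cc21`) gives 10000 nM. Compound 3 thus holds the second highest of the three numbers, higher than compound 1 and far lower than compound 2, both gaps beyond the scatter.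

Compound 4 (`CC(C)CCn1c(Cn2c(=O)n(C(C)C)c3ccccc32)nc2ccc(CN(C)C)cc21`) carries (dimethylamino)methyl in place of cyano on an aromatic carbon. No two measured compounds differ in one place only, so the size of this change has not been shown directly. Among the compounds with values here, the closest guide is compound 1, whose side group also ends in an amine and which gives 3270 nM, though that group differs from the one in compound 4 and sits elsewhere on the core. The expectation is a modest fall, estimated as a 2.0-fold lower number from compound 3 to compound 4 (0.30 log units; within the scatter), near the edge of the scatter. For compound 4 the expected value is 5000 nM, with an estimated range from 1500 nM to 16000 nM.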

Compound 4, half-maximal cytotoxic concentration: 26700 nM
Beside the measured number, compound 4's estimate is 5.3-fold (0.73 log units) below it; measured number above the stated range.
By their numbers in this assay, from the lowest: compound 1; then compound 3; then compound 4; then compound 2.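

In this assay the replacement of cyano by (dimethylamino)methyl on this aromatic carbon gives a 2.7-fold higher number from compound 3 to compound 4 (0.43 log units; beyond the scatter) and is the only step shown between compounds that differ in one place. At this position on the shared core, the change therefore moves the read-out toward lower toxicity in this test, by a modest amount that lies beyond the scatter. Nothing shown gives a measured reason for this step.

The compounds shown leave open whether the step follows the amine or the carbon that carries it; a primary amine or a plain ethyl group on this aromatic carbon would separate the two. Going by these compounds, it also remains open whether the same replacement gives a step of this size on a core that carries a carboxylic acid.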